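Cytotoxicity notes on the hydrazone aryl series

This account rests on a few compounds, and the source may have more. Where it says the series, first, only, none or still open, it means among the compounds named here.

Compound 1 `COc1ccc(/C=N/NC(=O)c2cnc3c(C(F)(F)F)cccc3c2N[C@@H](CSc2ccccc2)CC(=O)N(C)C)cc1` in an ADME assay on Vero cells (Chlorocebus sabaeus) for cytotoxicity, read by MTT assay, with a stated time of 72 h; on this read-out lower numbers stand for stronger inhibition and higher numbers for weaker inhibition: "not determined" (no result reported).
Compound 2 `CN(C)C(=O)C[C@H](CSc1ccccc1)Nc1c(C(=O)N/N=C/c2ccc(OC(F)(F)F)cc2)cnc2c(C(F)(F)F)cccc12` in this assay: > 62.5 ug/mL, a limit.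
Compound 3 `CN(C)C(=O)C[C@H](CSc1ccccc1)Nc1c(C(=O)N/N=C/c2cccnc2)cnc2c(C(F)(F)F)cccc12` in this assay: > 62.5 ug/mL, a limit.
Compound 4 `CN(C)C(=O)C[C@H](CSc1ccccc1)Nc1c(C(=O)N/N=C/c2ccc(Br)s2)cnc2c(C(F)(F)F)cccc12`: to be measured in this assay.

Compound 3 stands only at a limit in this assay. Compound 2 likewise gives only a limit, and compound 1 has no number. Among the compounds with values here, the one measured step, a step that the two limits leave unreadable from compound 2 to compound 3, cannot be sized because the limit of > 62.5 ug/mL in this assay, at which 2 of the 3 values shown sit, holds both of its ends. The change to compound 4 is 5-bromothiophen-2-yl in place of pyridin-3-yl on a carbon with a double bond to nitrogen. Within the data shown here, no measured step bears readably on this change, so no step beyond the scatter is expected in this assay, and a limit is again the likeliest outcome. Compound 4 is estimated at 62.5 ug/mL (range 30 ug/mL to 125 ug/mL), which means an expected step of a number no higher from compound 3 to compound 4 (the limit leaves the size open).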

Compound 4, half-maximal inhibitory concentration: > 62.5 ug/mL
Compound 4 was reported as a limit (the forecaster's own chance of this, stated with the estimate: 75%); the middle value lies on the limit itself.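

Neither the step from compound 3 to compound 4 nor the step from compound 2 to compound 4 can be read, because each pair sits at one limit: the limit of > 62.5 ug/mL in this assay, at which 3 of the 4 values shown sit.

The compounds shown leave open whether these aryl groups differ at all in this assay.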